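This account rests on a few compounds, and the source may have more. Where it says the series, first, only, none or still open, it means among the compounds named here.

Measured in a functional assay on A549 cells (Homo sapiens) for inhibition, read by sulforhodamine B assay, with a stated time of 48 h; a lower number here means a stronger inhibitor of growth, a higher number a weaker inhibitor of growth

- compound 1 `COc1cc(/C=C/C(=O)/C=C/c2sccc2C)cc(OC)c1OC` gives 9310 nM
- compound 2 `COc1ccc(/C=C/C(=O)C(=Cc2ccc(N(C)C)cc2)C(=O)/C=C/c2ccc(OC)c(OC)c2)cc1OC` gives 2620 nM
- compound 3 `COc1ccc(OC)c(C=C(C(=O)/C=C/c2ccc(O)c(OC)c2)C(=O)/C=C/c2ccc(O)c(OC)c2)c1` gives 670 nM

Compound 2 holds the middle place, with the second highest of the three numbers. Compound 1 lies higher and compound 3 lower, and both gaps are beyond the scatter.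

The next compound to read is compound 4 `COc1ccc(OC)c(C=C(C(=O)/C=C/c2ccc(OC)c(OC)c2)C(=O)/C=C/c2ccc(OC)c(OC)c2)c1`. Its change from compound 2 is 2,5-dimethoxyphenyl in place of 4-(dimethylamino)phenyl on a double-bonded chain carbon bound to a double-bonded chain carbon. In words, 2,5-dimethoxyphenyl replaces 4-(dimethylamino)phenyl on a double-bonded chain carbon bound to a double-bonded chain carbon.

Among the compounds with values here, no step between measured compounds isolates a single change, so the size of this one cannot be read directly from the data. The only scale is the spread of values, from compound 3 at 670 nM to compound 1 at 9310 nM. In this assay a small move towards a lower number is expected, probably not beyond the scatter, with a wide margin in either direction. The estimated step is a 1.7-fold lower number from compound 2 to compound 4 (0.24 log units; within the scatter). For compound 4 the estimated value is 1500 nM, with an expected range from 500 nM to 4500 nM.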

Compound 4, concentration for 50% growth inhibition: 530 nM
Estimate against measurement, compound 4: 2.8-fold (0.45 log units) above; measured number inside the range.
By their numbers in this assay, from the lowest: compounds 4 and 3 (each within the scatter of the next); then compound 2; then compound 1.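

In this assay, the group on a double-bonded chain carbon bound to a double-bonded chain carbon proves able to shift the number: 2,5-dimethoxyphenyl in place of 4-(dimethylamino)phenyl gives a 4.9-fold lower number from compound 2 to compound 4 (0.69 log units; beyond the scatter). Within the data shown here, this is the first step that isolates a change in one place, and both groups carry a six-membered aromatic ring of carbon only, so the step reflects a change of substituents on that ring. No supporting data bear on the origin of this step.

Going by these compounds, whether the step follows from losing the dimethylamino group or from gaining the two methoxy groups remains open, as does the role of their placement on the ring. A 4-methoxyphenyl or a pyridine ring at this position would help separate these readings.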